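The source may report more compounds than this note shows. Statements on the series, on what has been measured and on what is new or still open speak of the compounds shown alone.

Series notes. In a functional assay on DU-145 cells (Homo sapiens) for cytotoxicity, read by sulforhodamine B assay, with a stated time of 2 days, tested at 100 uM (on this read-out higher numbers stand for more inhibition at the one concentration tested (going by the name of the read-out) and lower numbers for less inhibition), compound 2 `O=C(Nn1c(-c2cccc([N+](=O)[O-])c2)nc2c(CCc3ccccc3)n[nH]c2c1=O)c1ccccc1` gives 92.5%. Compound 1 `CCCc1n[nH]c2c(=O)n(NC(=O)c3ccccc3)c(-c3cccc([N+](=O)[O-])c3)nc12` differs from it by methyl in place of phenyl on a saturated chain carbon, two bonds along the chain from an aromatic carbon, and in this assay compound 1 gives 27.8%, so the change made a number 64.7 percentage points lower from compound 2 to compound 1 (beyond the scatter). Compound 3 `O=C(Nn1c(CCc2ccccc2)nc2c(-c3ccc(Cl)cc3)n[nH]c2c1=O)c1ccccc1` carries a different core; how its core differs from that of compound 2 is not broken down here. In this assay compound 3 gives 85.6%, a number within the scatter of the value of compound 2.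

Compound 4 `CCCc1nc2c(-c3ccc(Cl)cc3)n[nH]c2c(=O)n1NC(=O)c1ccccc1` differs from compound 3 by methyl in place of phenyl on a saturated chain carbon, two bonds along the chain from an aromatic carbon, at a place described in the same words as for the change from compound 2 to compound 1, so it counts as the same change on the other core. Going by the values given here, whether a second core carries the step along is untested; only one earlier example exists.

For compound 4 in this assay the step is estimated as a number 55.6 percentage points lower from compound 3 to compound 4 (beyond the scatter) because the same change gave a number 64.7 percentage points lower from compound 2 to compound 1 (beyond the scatter). Compound 4 is expected near 30%, between 10% and 60%.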

Compound 4, a percentage reported as inhibition, at one concentration (the size of the read-out at that concentration, not a potency): 89.4%
The estimate for compound 4 lay 59.4 percentage points below the measured number, and the stated range ends below it.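

In this assay the change from phenethyl to propyl does not carry over from the core of compound 2 to the core of compound 3, and on the second core the step is a number 3.8 percentage points higher from compound 3 to compound 4 (within the scatter). Set side by side, the two steps disagree: the same change on two cores in this assay, a number 64.7 percentage points lower (beyond the scatter) from compound 2 to compound 1 and a number 3.8 percentage points higher (within the scatter) from compound 3 to compound 4, 68.5 percentage points apart, beyond the scatter of two such steps This shows that the large step on the first core cannot be read as a general result of the change in this series, but it does not show which feature of the two cores lies behind the gap, and each core rests on a single pair of compounds.

Still open, on these data alone, is whether a longer chain such as butyl, or a chain ending in an amine or a carboxylic acid, would follow the core of compound 2 or the core of compound 3. Also open, as far as these compounds go, is whether these readings at a single concentration would hold up as a difference in potency.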